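A few compounds are considered here, and "the series" means these few. Any claim that something is new, unique, unknown or untested is made for them only; others in the source may bear on it.

Of the compounds shown here, three that share an unsaturated amide side chain have been tested in a functional assay on A549 cells (Homo sapiens) for cytotoxicity, read by CCK-8 assay, with a stated time of 24 h; a lower number here means a stronger inhibitor, a higher number a weaker inhibitor. Compound 1 `C=C1CCC(c2csc(/C=C(\C)C(N)=O)c2)CC1` carries a saturated ring with an exocyclic double bond. In this assay compound 1 gives only a limit, > 50000 nM, and not a number. Compound 2 `C/C(=C\c1cc(C2=CCCCC2)co1)C(N)=O` is built around a different aromatic ring. Compound 2 also reaches only the limit, > 50000 nM, in this assay. Compound 3 `C/C(=C\c1cc(-c2ccc(C#N)cc2)cs1)C(N)=O` carries a cyano group on a six-membered aromatic ring of carbon only. For compound 3 this assay again reports only a limit, > 50000 nM, not a number. All three values sit at the same limit (the limit of > 50000 nM in this assay, at which 3 of the 3 values shown sit), so compound 3 cannot be placed above or below the other two on the numbers shown.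

Compound 4 `COc1ccc(-c2csc(/C=C(\C)C(N)=O)c2)cc1` differs from compound 3 by methoxy in place of cyano on an aromatic carbon. For the measured compounds named here, no pair of measured compounds differs in one place, so there is no measured step to lean on. Going by the values given here, the only footing is that compound 3 shows no measurable inhibition at > 50000 nM. The step is therefore expected to be a step that the limit leaves unreadable from compound 3 to compound 4, nothing beyond the scatter. Compound 4 is expected to give about 80000 nM, within a range from 30000 nM to 250000 nM, most likely reported again only as a limit.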

Compound 4, half-maximal inhibitory concentration: > 50000 nM
Compound 4: a limit, no number; the forecaster's own chance of this, stated with the estimate: 85%; the middle value is on the limit's open side.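

In this assay, for the compounds shown here, compound 4 also gives only a limit, so no step from compound 3 to compound 4 can be read, because both compounds sit at the same limit: the limit of > 50000 nM in this assay, at which 4 of the 4 values shown sit.

The compounds shown leave open how cyano and methoxy compare in this assay and whether any compound of this kind gives an actual number there.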